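Mirror image of the hydroxyphenyl analogue

The compounds below may be only part of what the source reports. "The series", "measured", "known", "first", "only" and "open" are said of these compounds alone.

Compound 1 `OC[C@]1(c2ccccc2)NC[C@H](O)[C@H]1O` gives 630 nM in an assay on isolated protein for inhibition of lysosomal alpha-glucosidase (Homo sapiens); a higher number here means a weaker inhibitor, a lower number a stronger inhibitor. Compound 2 `OC[C@]1(c2ccc(O)cc2)NC[C@H](O)[C@H]1O` gives 376000 nM, the highest number of the two, the step being a 600-fold higher number from compound 1 to compound 2 (2.78 log units; beyond the scatter). Compound 3 `OC[C@@]1(c2ccc(O)cc2)NC[C@@H](O)[C@@H]1O` is its mirror image: the two compounds have the same atoms and bonds and differ only in configuration as drawn: 3 of 3 stereo elements differ (all stereocentres are inverted: mirror images); a stereocentre at a saturated ring carbon is drawn S in compound 2 and R in compound 3; a stereocentre at a saturated ring carbon is drawn S in compound 2 and R in compound 3; a stereocentre at a saturated ring carbon is drawn S in compound 2 and R in compound 3. For the measured compounds named here, no measured step inverts all stereocentres, so nothing here says whether the change raises or lowers the number; the one step known concerns the hydroxy group and not configuration. Compound 3 is expected near compound 2, its number estimated at 500000 nM, between 40000 nM and 6000000 nM, a step of a 1.3-fold higher number from compound 2 to compound 3 (0.12 log units; within the scatter).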

Compound 3, half-maximal inhibitory concentration: 372000 nM
Compound 3: the middle estimate sits 1.3-fold (0.13 log units) above what was measured, within the range that was stated.
By their numbers in this assay, from the lowest: compound 1; then compounds 3 and 2 (each within the scatter of the next).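

In this assay, for the compounds shown here, inverting all stereocentres gives a 1.0-fold lower number from compound 2 to compound 3 (0.00 log units; within the scatter), the first step that changes configuration and not a group. With the hydroxy group on the aromatic ring, the two mirror images cannot be told apart, so this assay shows no preference between them. The comparison concerns configuration alone: the fact that compounds 2 and 3 differ only in the configuration as drawn

On these data alone, whether inversion would also leave the number unchanged without the hydroxy group, in the mirror image of compound 1, remains open. So does the outcome with a methoxy group or an amine in its place.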